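The compounds below may be only part of what the source reports. "The series", "measured", "known", "first", "only" and "open" are said of these compounds alone.

Compound 1 `COc1cc(-c2nnc(SCC(=O)c3ccccc3F)n2N)cc(OC)c1OC` is a ketone carrying a 2-fluorophenyl group. For the measured compounds named here, in a functional assay on PC-3 cells (Homo sapiens) for antiproliferative activity, read by MTT assay, with a stated time of 48 h (on this read-out higher numbers stand for weaker inhibition and lower numbers for stronger inhibition), compound 1 gives 43100 nM, the only exact number in this set. Compound 2 `COc1cc(NC(=O)CSc2nnc(-c3cc(OC)c(OC)c(OC)c3)n2N)cc(OC)c1OC` gives > 100000 nM in this assay, which is a limit of the measurement rather than a number (the limit of > 100000 nM in this assay, at which 1 of the 2 values shown sits). The unmeasured compound 3 `COc1cc(-c2nnc(SCC(=O)NCc3ccc(Cl)cc3)n2N)cc(OC)c1OC` differs from compound 1 by (4-chlorobenzyl)amino in place of 2-fluorophenyl on a carbonyl carbon. Going by the values given here, no measured step of this kind exists, so the change from compound 1 to compound 3 is expected to alter potency little, perhaps slightly toward weaker inhibition, with an expected step of a 1.4-fold higher number from compound 1 to compound 3 (0.14 log units; within the scatter). Compound 3 is therefore estimated at 60000 nM, between 15000 nM and 200000 nM.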

Compound 3, half-maximal inhibitory concentration: > 100000 nM
Compound 3: a limit, no number; the forecaster's own chance of this, stated with the estimate: 35%; middle value at least 1.6-fold (0.22 log units) from the limit.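

Compound 3 gives > 100000 nM in this assay, which is a limit and not a number. For the compounds shown here, this provides the first measured step on this carbonyl carbon, an at least 2.3-fold higher number from compound 1 to compound 3 (0.36 log units; beyond the scatter), so replacing 2-fluorophenyl with (4-chlorobenzyl)amino does weaken inhibition here. The full size of the step cannot be read because only its lower end is fixed: the limit of > 100000 nM in this assay, at which 2 of the 3 values shown sit.

As far as these compounds go, it remains open whether the fluorine, the amide hydrogen or the 4-chloro group matters most. A plain phenyl or an unsubstituted benzylamino group on this carbon would help separate these parts.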